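The source may report more compounds than this note shows. Statements on the series, on what has been measured and on what is new or still open speak of the compounds shown alone.

Compound 3 `COc1ncc(-c2cc3c(C)nc(N)nc3n([C@H]3CC[C@H](OCO)CC3)c2=O)cc1F` gives 5.24 nM in an assay on BT-20 cells for inhibition of RAC-alpha serine/threonine-protein kinase (Homo sapiens) (on this read-out higher numbers stand for weaker inhibition and lower numbers for stronger inhibition), the lowest of the two numbers shown. Compound 2 `Cc1nc(N)nc2c1cc(-c1cn[nH]c1)c(=O)n2[C@H]1CC[C@@H](OCO)CC1` gives 11.2 nM in this assay, a number higher by more than the usual scatter. For compound 1 `COc1ncc(-c2cc3c(C)nc(N)nc3n([C@H]3CC[C@@H](OCO)CC3)c2=O)cc1F` this assay reports "not determined" (no result reported); it is worth noting (the fact that compounds 1 and 3 differ only in the configuration as drawn). Compound 4 `Cc1nc(N)nc2c1cc(-c1cn[nH]c1)c(=O)n2[C@H]1CC[C@H](OCO)CC1` has not yet been measured. It differs from compound 3 in one place: 1H-pyrazol-4-yl in place of 5-fluoro-6-methoxypyridin-3-yl on an aromatic carbon. Among the compounds with values here, no step between measured compounds covers exactly this change. Compound 4 is expected to show a moderate step toward weaker inhibition, a 1.9-fold higher number from compound 3 to compound 4 (0.28 log units; within the scatter), because compound 2 carries the same 1H-pyrazol-4-yl group and gives 11.2 nM. Compound 4 is therefore estimated at 10 nM, with a range from 4 nM to 25 nM.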

Compound 4, half-maximal inhibitory concentration: 25.9 nM
Compound 4: middle estimate off by 2.6-fold (0.41 log units), on the low side; measured number outside the range, above it.
By their numbers in this assay, from the lowest: compound 3; then compound 2; then compound 4.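

Swapping 5-fluoro-6-methoxypyridin-3-yl for 1H-pyrazol-4-yl on this aromatic carbon weakens inhibition in this assay, with a 4.9-fold higher number from compound 3 to compound 4 (0.69 log units; beyond the scatter). Configuration on the saturated ring also counts by itself, with a 2.3-fold higher number from compound 2 to compound 4 (0.36 log units; beyond the scatter), and this comparison isolates that single feature: the fact that compounds 2 and 4 differ only in the configuration as drawn.

As far as these compounds go, whether configuration acts the same way with 5-fluoro-6-methoxypyridin-3-yl stays open, as compound 1 gives "not determined" (no result reported): the fact that compounds 1 and 3 differ only in the configuration as drawn. From the compounds shown here alone, how an amine or a longer carbon chain on this aromatic carbon would read also remains open.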